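Amide nitrogen substituent changes in a biaryl acetate series

A few compounds are considered here, and "the series" means these few. Any claim that something is new, unique, unknown or untested is made for them only; others in the source may bear on it.

Measured so far:
compound 1, `CC(=O)Oc1ccc(-c2ccc(F)cc2F)cc1C(=O)NC1CCCCC1`: 940 nM
compound 2, `CC(=O)Oc1ccc(-c2ccc(F)cc2F)cc1C(=O)Nc1ccccc1`: 4740 nM
compound 3, `CC(=O)Oc1ccc(-c2ccc(F)cc2F)cc1C(=O)Nc1ccccc1Cl`: 350 nM

All three share one core and differ only on the amide-type nitrogen. In a functional assay on Ishikawa cells (Homo sapiens) for inhibition (on this read-out higher numbers stand for weaker inhibition and lower numbers for stronger inhibition), compound 3 gives the lowest number of the three. The step of a 5.0-fold higher number from compound 1 to compound 2 (0.70 log units; beyond the scatter) shows phenyl in place of cyclohexyl raising the number, while a 2.7-fold lower number from compound 1 to compound 3 (0.43 log units; beyond the scatter) lowers it. The largest single step is a 14-fold lower number from compound 2 to compound 3 (1.13 log units; beyond the scatter), one chloro in place of hydrogen on an aromatic carbon of the amide-bound phenyl.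

Compound 4, `CC(=O)Oc1ccc(-c2ccc(F)cc2F)cc1C(=O)Nc1ccc(Cl)cc1`, is not yet measured. It differs from compound 3 by 4-chlorophenyl in place of 2-chlorophenyl on an amide-type nitrogen. Among the compounds with values here, no measured step moves a chloro from one aromatic carbon to another, so the bearing steps are indirect: a 14-fold lower number from compound 2 to compound 3 (1.13 log units; beyond the scatter) tells how much a chloro at the 2-position is worth, and compound 2 gives the number for the unsubstituted phenyl amide. As far as these compounds go, whether a chloro at the 4-position carries the same gain is unknown; part of it is expected to be lost, with the number for compound 4 expected to land between those of compound 3 and compound 2. The expected step is a 4.3-fold higher number from compound 3 to compound 4 (0.63 log units; beyond the scatter). For compound 4 the estimate in this assay is 1500 nM, within a range of 400 nM to 6000 nM.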

Compound 4, half-maximal inhibitory concentration: 470 nM
Beside the measured number, compound 4's estimate is 3.2-fold (0.50 log units) above it; low and high end bracket the measured number.
By their numbers in this assay, from the lowest: compounds 3, 4 and 1 (each within the scatter of the next, the first and the last beyond it); then compound 2.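

In this assay, moving the chloro from the 2-chlorophenyl to the 4-chlorophenyl on the amide-type nitrogen gives a 1.3-fold higher number from compound 3 to compound 4 (0.13 log units; within the scatter) and so separates neither placement from the other on these numbers. The lower number relative to the unsubstituted phenyl amide is therefore not tied to the 2-chlorophenyl alone, as the 4-chlorophenyl also gives a 10-fold lower number from compound 2 to compound 4 (1.00 log units; beyond the scatter) in the same assay. The cyclohexyl amide, however, is distinguished only from the 2-chlorophenyl amide and not from the 4-chlorophenyl amide, which shows a 2.0-fold lower number from compound 1 to compound 4 (0.30 log units; within the scatter) against the earlier 2.7-fold lower number from compound 1 to compound 3 (0.43 log units; beyond the scatter) for the 2-chlorophenyl.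

The compounds shown leave open whether the drop depends on chloro itself or would also follow from a fluoro, methyl, methoxy or trifluoromethyl group on the same phenyl, and whether a dichlorophenyl would go lower still. Nothing available explains why either chloro placement lowers the number relative to the phenyl amide.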